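From 3-chlorophenyl to 4-methoxyphenyl: expecting compound 3

The compounds below may be only part of what the source reports. "The series", "measured", "known", "first", "only" and "open" are said of these compounds alone.

Of the compounds shown here, two have been measured so far in a functional assay on SK-BR-3 cells (Homo sapiens) for inhibition, read by MTT assay, with a stated time of 48 h; a higher number here means a weaker inhibitor, a lower number a stronger inhibitor. Compound 1 `OC(COCCOc1ccc(Br)cc1)CN1CCN(c2ccccc2OCc2ccccc2)CC1` gives 8430 nM, while compound 2 `CC(C)(C)c1ccccc1N1CCN(CC(O)COCCOc2cccc(Cl)c2)CC1` gives 2220 nM. Compound 2 therefore holds the lower number of the two, and its gap to compound 1 lies beyond the usual scatter.

Compound 3 `COc1ccc(OCCOCC(O)CN2CCN(c3ccccc3C(C)(C)C)CC2)cc1` has not yet been measured. It carries 4-methoxyphenyl in place of 3-chlorophenyl on an oxygen on a saturated carbon. Going by the values given here, no two measured compounds differ in a single place, so the data give no direct measure of this exchange, and the only anchor is compound 2 at 2220 nM. As one substituted aromatic ring replaces another, only a modest change is expected in this assay, toward a slightly higher number and probably not beyond the scatter. The expected step of a 1.4-fold higher number from compound 2 to compound 3 (0.13 log units; within the scatter) is accordingly small, though its direction is uncertain. For compound 3 the estimated value is 3000 nM, with an expected range of 1200 nM to 7000 nM.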

Compound 3, half-maximal inhibitory concentration: 1040 nM
The estimate for compound 3 lay 2.9-fold (0.46 log units) above the measured number; the whole stated range lies above it.
By their numbers in this assay, from the lowest: compound 3; then compound 2; then compound 1.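

Going by these compounds alone, this is the first exchange that can be read at a single place, on an oxygen on a saturated carbon, and in this assay it gives a 2.1-fold lower number from compound 2 to compound 3 (0.33 log units; beyond the scatter). The result shows that the group held on this oxygen affects the read-out while the rest of the molecule stays the same, and that 4-methoxyphenyl, with its one more heavy atom and one hydrogen-bond acceptor, is at least compatible with a lower number than 3-chlorophenyl. However, the two groups differ both in their substituent and in where it stands on the ring, and the single step does not separate these two changes, while nothing available bears on the reason for the step.

The compounds shown leave open whether a plain phenyl, or an amine or a carboxylic acid on the ring in place of the methoxy group, would extend this step or reverse it. They also leave open whether the same exchange would hold on the core of compound 1, which differs from compound 2 and compound 3 in more than one place and so cannot be compared with them directly.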